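Swapping a Fluorophenyl for a Thiazolyl on the Core

This account rests on a few compounds, and the source may have more. Where it says the series, first, only, none or still open, it means among the compounds named here.

Of the compounds shown here, three that share one core have been tested. In an assay on isolated protein for inhibition of acid ceramidase (Homo sapiens), read by LC-MS, with a stated time of 1 h (a lower number here means a stronger inhibitor, a higher number a weaker inhibitor), compound 1 `CCCCCNC(=O)n1c(-c2ccccc2)coc1=O` gives 25 nM. In this assay compound 2 `CCOCCNC(=O)n1cc(-c2ccccc2)oc1=O` gives 2040 nM. In this assay compound 3 `O=C(NCCCCc1ccccc1)n1cc(-c2ccc(F)cc2)oc1=O` gives 185 nM. Among these three numbers compound 3 stands second highest: compound 1 lies nearest, with a lower number, and compound 2 lies furthest, with a higher number, both gaps beyond the scatter.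

Compound 4 `O=C(NCCCCc1ccccc1)n1cc(-c2cscn2)oc1=O` differs from compound 3 in one place: 1,3-thiazol-4-yl in place of 4-fluorophenyl on an aromatic carbon. The 4-fluorophenyl leaves and a 1,3-thiazol-4-yl enters, one five-membered aromatic ring with 2 hetero atoms replacing one six-membered aromatic ring of carbon only. Going by the values given here, no measured pair shows this kind of swap, so no step can be read from the data. The step is expected to be modest, a 1.7-fold higher number from compound 3 to compound 4 (0.24 log units; within the scatter), leaning toward a somewhat higher number, though a result within the scatter would not surprise. For compound 4 the estimate in this assay is 320 nM, with a range from 80 nM to 1300 nM.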

Compound 4, half-maximal inhibitory concentration: 44 nM
Beside the measured number, compound 4's estimate is 7.3-fold (0.86 log units) above it, outside the stated range (below it).
By their numbers in this assay, from the lowest: compounds 1 and 4 (each within the scatter of the next); then compound 3; then compound 2.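

In this assay, putting 1,3-thiazol-4-yl in place of 4-fluorophenyl, on the aromatic carbon next to the ring oxygen, gives a 4.2-fold lower number from compound 3 to compound 4 (0.62 log units; beyond the scatter). Going by these compounds alone, this is the first pair here that differs in one place, and so the first direct reading of this position. It shows that the group at this place need not be a six-membered aromatic ring of carbon only, since a five-membered aromatic ring with 2 hetero atoms gives the stronger inhibitor of the two. No measurement on hand accounts for this gain.

Going by these compounds, it remains open whether a pyridin-3-yl or a 1,3-oxazol-4-yl group at this place would match the 1,3-thiazol-4-yl. The compounds shown also leave open whether the same swap would give a similar step with a plain butyl chain on the amide nitrogen.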